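This account rests on a few compounds, and the source may have more. Where it says the series, first, only, none or still open, it means among the compounds named here.

Measured compounds in a functional assay on UO-31 cells (Homo sapiens) for inhibition, read by sulforhodamine B assay, with a stated time of 48 h; a lower number here means that less compound is tolerated, a higher number that more compound is tolerated:
Compound 1 `Nc1cc(N)c2nc(-c3ccccc3)c(Oc3ccc(Cl)c(Cl)c3)nc2c1` gives < 100000 nM, which is a limit of the assay.
Compound 2 `CCOC(=O)[C@H](CCC(=O)O)NC(=O)c1ccc(CNc2nc3cc(N)cc(N)c3nc2-c2ccccc2)cc1` gives < 100000 nM, which is a limit of the assay.
Compound 3 `Nc1cc(N)c2nc(-c3ccccc3)c(NCc3ccc(Cl)c(Cl)c3)nc2c1` gives < 100000 nM, which is a limit of the assay.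

Compound 3 thus has no position on a numerical scale yet: its result in this assay is only a limit, and the two other values shown are limits of the same kind, so no ordering among the three compounds can be read from them. The common picture of the set is the limit of < 100000 nM in this assay, at which 3 of the 3 values shown sit.

The step to compound 4 `COc1ccc(CNc2nc3cc(N)cc(N)c3nc2-c2ccccc2)cc1` is 4-methoxyphenyl in place of 3,4-dichlorophenyl on a saturated chain carbon bound to a nitrogen on an aromatic ring. For the measured compounds named here, no step between two measured compounds is available, so the size of this change cannot be anchored on any measured number in the set. With all three known results sitting at the same limit, the working expectation is that compound 4 will again be reported close to that limit, with no direction beyond the scatter; the step from compound 3 to compound 4 is estimated as a step that the limit leaves unreadable from compound 3 to compound 4. Compound 4 is expected at about 30000 nM, within a range of 5000 nM to 100000 nM.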

Compound 4, concentration lethal to 50% of the cells: 72400 nM
Compound 4: middle estimate off by 2.4-fold (0.38 log units), on the low side; low and high end bracket the measured number.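

No new step can be read between compound 3 and compound 4, because compound 3 carries only a limit in this assay: the limit of < 100000 nM in this assay, at which 3 of the 4 values shown sit.
The compounds shown leave open how far 4-methoxyphenyl in place of 3,4-dichlorophenyl shifts the read-out, and how compound 1, compound 2 and compound 3 rank among themselves.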